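Bromine on the Fused Ring: What to Expect from Compound 4

The source may hold more compounds than are shown below. What is called first, only, known or untested is meant among the compounds shown, and "the series" means these compounds.

Compound 1 `COc1ccc(C2=NN(C3=NC(=O)/C(=C4\C(=O)Nc5ccccc54)S3)C(c3ccc(Cl)cc3)C2)cc1` and compound 2 `COc1ccc(C2=NN(C3=NC(=O)/C(=C4\C(=O)Nc5ccc(Br)cc54)S3)C(c3ccc(Cl)cc3)C2)cc1` share one core and differ in a single place. In a functional assay on cells (Cancer cell lines, Homo sapiens) for cytotoxicity, read by sulforhodamine B assay, with a stated time of 48 h (a higher number here means a weaker inhibitor of growth, a lower number a stronger inhibitor of growth), compound 1 gives 100000 nM, while compound 2 gives 14700 nM. The change between them, (bromo in place of hydrogen on an aromatic carbon), produced a 6.8-fold lower number from compound 1 to compound 2 (0.83 log units; beyond the scatter). Compound 3 `CN(C)c1ccc(C2CC(c3ccccc3)=NN2C2=NC(=O)/C(=C3\C(=O)Nc4ccccc43)S2)cc1` is built on a different core; the difference between the two cores is not broken down here. In this assay compound 3 gives 39700 nM, a number that sits between those of compound 1 and compound 2. Compound 4 `CN(C)c1ccc(C2CC(c3ccccc3)=NN2C2=NC(=O)/C(=C3\C(=O)Nc4ccc(Br)cc43)S2)cc1` has not yet been measured. Among the measured compounds shown here, it differs from compound 3 by bromo in place of hydrogen on an aromatic carbon, which is the same change as the one from compound 1 to compound 2, at the same kind of place on the ring. For the measured compounds named here, only that one earlier pair shows what this change does, so the expectation for compound 4 rests on the single step from compound 1 to compound 2. Compound 4 is expected to show a 5.7-fold lower number from compound 3 to compound 4 (0.75 log units; beyond the scatter) in this assay, a step close in size to a 6.8-fold lower number from compound 1 to compound 2 (0.83 log units; beyond the scatter). The estimated value for compound 4 in this assay is 7000 nM, with a likely range from 2500 nM to 20000 nM.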

Compound 4, concentration for total growth inhibition: 690 nM
Estimate against measurement, compound 4: 10-fold (1.01 log units) above; measured number below the stated range.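

In this assay, bromo in place of hydrogen on an aromatic carbon gave a 58-fold lower number from compound 3 to compound 4 (1.76 log units; beyond the scatter). The number therefore fell on both cores, but the size of the step did not carry over from one core to the other: the same change on two cores in this assay, a 6.8-fold lower number (0.83 log units; beyond the scatter) from compound 1 to compound 2 and a 58-fold lower number (1.76 log units; beyond the scatter) from compound 3 to compound 4, 8.5-fold (0.93 log units) apart, beyond the scatter of two such steps

The direction of the change held in both pairs, so a step measured on one core was a fair guide to direction in this small set, but not to size. Among the compounds shown here, with only two pairs, and with cores that differ in more than one place, the data do not show which part of the core goes with the larger step, or whether a third core would follow either pair.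

The compounds shown carry only hydrogen or bromo at this place on the ring, so it remains open whether chloro, a methoxy group or an amine there would also lower the number. Going by these compounds, it also remains open whether bromo on another carbon of the same ring would give a step of similar size on either core.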